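Cyclopentyl to 3-Cyanobenzyl: an Unmeasured Analogue

The source may report more compounds than this note shows. Statements on the series, on what has been measured and on what is new or still open speak of the compounds shown alone.

Compound 1 `COc1ccc([C@@H]2CC(=O)c3c(O)cc(OCc4cn(C5CCCC5)nn4)cc3O2)cc1O` gives 10500 nM in a functional assay on RAW264.7 cells (Mus musculus) for inhibition, read by Griess assay, with stated times of 2 h and 24 h; on this read-out lower numbers stand for stronger inhibition and higher numbers for weaker inhibition.
Compound 2 `C#CCOc1cc(O)c2c(c1)O[C@H](c1ccc(OC)c(O)c1)C/C2=N\O` gives 19100 nM.
Compound 3 `COc1ccc([C@@H]2C/C(=N\O)c3c(O)cc(OCc4cn(Cc5ccccc5F)nn4)cc3O2)cc1O` gives 5710 nM.

Among the three compounds measured in this assay, compound 1 holds the second highest number, yet its gaps to both compound 2 and compound 3 lie within the scatter of repeated measurements, so no order among the three can be claimed. Compound 4 `COc1ccc([C@@H]2CC(=O)c3c(O)cc(OCc4cn(Cc5cccc(C#N)c5)nn4)cc3O2)cc1O` has not yet been measured. It differs from compound 1 in one place: 3-cyanobenzyl in place of cyclopentyl on an aromatic nitrogen. Within the data shown here, no pair of measured compounds isolates this change, since compound 3, which also bears a substituted benzyl on that aromatic nitrogen, differs from compound 1 in its core as well. The expected step is a 1.3-fold lower number from compound 1 to compound 4 (0.12 log units; within the scatter), no larger than the scatter. The slight lean toward a lower number rests on compound 3, which gives 5710 nM with a benzyl group in the same place. Compound 4 is expected to give 8000 nM, with a range from 3000 nM to 25000 nM.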

Compound 4, half-maximal inhibitory concentration: 18000 nM
The estimate for compound 4 lay 2.3-fold (0.35 log units) below the measured number, and the stated range covers the measured number.
By their numbers in this assay, from the lowest: compounds 3, 1, 4 and 2 (each within the scatter of the next, the first and the last beyond it).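

Among these compounds, with the core held fixed, this is the first direct reading of the substituent on the aromatic nitrogen in this assay and it gives a 1.7-fold higher number from compound 1 to compound 4 (0.23 log units; within the scatter) for 3-cyanobenzyl in place of cyclopentyl. Exchanging a five-membered non-aromatic ring of carbon only for a larger group with a six-membered aromatic ring and a nitrile leaves the read-out inside the scatter, so the two groups cannot be ranked at this position. The earlier compounds shown here could not show this: compound 2 and compound 3 both differ from compound 1 in more than one place.

On these data alone, whether an unsubstituted benzyl, a longer alkyl chain, or a group bearing an amine or a carboxylic acid on this aromatic nitrogen would move the number beyond the scatter stays open on the shared core. Nothing available here offers an explanation for the step.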